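This account rests on a few compounds, and the source may have more. Where it says the series, first, only, none or still open, it means among the compounds named here.

Measured in a functional assay (Homo sapiens) for inhibition; a lower number here means a stronger inhibitor, a higher number a weaker inhibitor:
compound 1 `CS(=O)(=O)c1ccc(CSc2nc(-c3ccc(F)cc3)c(-c3ccncc3)[nH]2)cc1` gives 330 nM
compound 2 `Oc1ccccc1CSc1nc(-c2ccc(F)cc2)c(-c2ccncc2)[nH]1` gives 440 nM
compound 3 `CSc1cc(CSc2nc(-c3ccc(F)cc3)c(-c3ccncc3)[nH]2)ccc1O` gives 280 nM

Compound 3 cannot be separated from the other two compounds. The numbers show a 1.2-fold lower number from compound 1 to compound 3 (0.07 log units; within the scatter) and a 1.6-fold lower number from compound 2 to compound 3 (0.20 log units; within the scatter).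

In going to compound 4 `C[S+]([O-])c1ccc(O)c(CSc2nc(-c3ccc(F)cc3)c(-c3ccncc3)[nH]2)c1` the change is a group of 10 heavy atoms (7 carbon, 2 oxygen, 1 sulfur; one six-membered aromatic ring of carbon only) in place of a group of 9 heavy atoms (7 carbon, 1 oxygen, 1 sulfur; one six-membered aromatic ring of carbon only), on a saturated chain carbon bound to a sulfur, and the 4-hydroxy-3-(methylsulfanyl)phenyl group leaves. The measured steps that bear on this are the three exchanges at the same place. Besides the two above, there is a 1.3-fold higher number from compound 1 to compound 2 (0.12 log units; within the scatter). All three stay within the scatter, although the groups exchanged differ considerably. Among the measured compounds shown here, no measured compound carries the entering group, so this is indirect evidence only.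

No step beyond the scatter is therefore expected in this assay, and no direction is predicted. The expected result is a 1.1-fold higher number from compound 3 to compound 4 (0.03 log units; within the scatter). For compound 4 the estimated value is 300 nM, with an expected range from 130 nM to 700 nM.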

Compound 4, half-maximal inhibitory concentration: 1000 nM
The estimate for compound 4 lay 3.3-fold (0.52 log units) below the measured number; measured number above the stated range.
By their numbers in this assay, from the lowest: compounds 3, 1 and 2 (each within the scatter of the next); then compound 4.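

In this assay this place no longer looks indifferent: the group of 10 heavy atoms in compound 4 gives steps beyond the scatter against all three earlier compounds, with a 3.6-fold higher number from compound 3 to compound 4 (0.55 log units; beyond the scatter), a 2.3-fold higher number from compound 2 to compound 4 (0.36 log units; beyond the scatter) and a 3.0-fold higher number from compound 1 to compound 4 (0.48 log units; beyond the scatter). The groups of compound 1 and compound 4 have the same heavy-atom composition, and the groups of compound 3 and compound 4 have the same counts of hydrogen-bond donors and acceptors, so neither match keeps the number within the scatter. No supporting data accompany this rise to account for it.

Open, from the compounds shown here alone, is whether the rise follows the sulfur group itself or the arrangement of substituents on the aromatic ring, since compound 3 and compound 4 differ in both. Also open, going by these compounds, is how an amine, a carboxylic acid or a longer chain at this place would read in this assay.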